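The source may hold more compounds than are shown below. What is called first, only, known or untested is meant among the compounds shown, and "the series" means these compounds.

Measured compounds:
- compound 1 `CN(C)c1ccc(/C=C/C(=O)c2ccc(N(C)C)cc2O)cc1`: 12100 nM
- compound 2 `CCN(CCCCCCOc1ccc(C(=O)/C=C/c2ccc(N(C)C)cc2)c(O)c1)Cc1ccccc1`: 2100 nM

In an assay on isolated protein for inhibition of Amine oxidase [flavin-containing] B (Homo sapiens) (a higher number here means a weaker inhibitor, a lower number a stronger inhibitor), compound 2 gives the lowest of the two numbers, with compound 1 the nearest at a higher value, a gap beyond the scatter. Compound 3 `CCN(CCCCCCOc1ccc(C(=O)/C=C/c2ccc(N(C)C)cc2)c(O)c1)Cc1ccccc1N(C)C` differs from compound 2 by dimethylamino in place of hydrogen on an aromatic carbon, ortho to a large group, on the benzyl end of the chain. Going by the values given here, no step between measured compounds bears on this change, so no direction can be taken from the data. The step from compound 2 to compound 3 is expected to be small, likely within the scatter: a 1.2-fold lower number from compound 2 to compound 3 (0.07 log units; within the scatter). Compound 3 is estimated at 1800 nM, with a range from 600 nM to 5500 nM.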

Compound 3, half-maximal inhibitory concentration: 2100 nM
Compound 3: middle estimate off by 1.2-fold (0.07 log units), on the low side; low and high end bracket the measured number.
By their numbers in this assay, from the lowest: compounds 2 and 3 (each within the scatter of the next); then compound 1.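

In this assay, going by these compounds alone, dimethylamino in place of hydrogen on the benzyl end of the chain, ortho to a large group, gives no change at the digits printed from compound 2 to compound 3 (within the scatter) and is the first single-place step. This aromatic carbon therefore accepts the added group, and the 2-(dimethylamino)benzyl end holds the level of the plain benzyl end. Nothing on hand accounts for this outcome.

Still open, on these data alone, is whether a carboxylic acid or a methoxy group on this carbon would read the same. Also open, as far as these compounds go, is whether a longer chain would alter the level with either benzyl end.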